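The source may hold more compounds than are shown below. What is called first, only, known or untested is meant among the compounds shown, and "the series" means these compounds.

Measured compounds:
- compound 1, `CNC(=O)[C@H]1O[C@@H](n2cnc3c(NC)nc(Cl)nc32)[C@H](O)[C@@H]1O`: 0.282 nM
- compound 2, `CNc1nc(Cl)nc2c1ncn2[C@@H]1O[C@H](C(=O)NCCC(C)C)[C@@H](O)[C@H]1O`: 1.62 nM
- compound 3, `CNc1nc(Cl)nc2c1ncn2[C@@H]1O[C@H](C(=O)NCc2cccc(F)c2)[C@@H](O)[C@H]1O`: 17.4 nM

In an assay on CHO cells for displacement of a labelled ligand from adenosine receptor A3 (Homo sapiens) (a lower number here means a stronger inhibitor, a higher number a weaker inhibitor), compound 1 gives 0.282 nM, the lowest of the three numbers. The other two compounds carry extra groups on a saturated chain carbon bound to an amide-type nitrogen, and each such addition raises the number: a 5.7-fold higher number from compound 1 to compound 2 (0.76 log units; beyond the scatter) and a 62-fold higher number from compound 1 to compound 3 (1.79 log units; beyond the scatter), with an 11-fold higher number from compound 2 to compound 3 (1.03 log units; beyond the scatter) between them.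

Compound 4, `CNC(=O)[C@H]1O[C@@H](n2cnc3c(NC4CCCC4)nc(Cl)nc32)[C@H](O)[C@@H]1O`, is not yet measured. It differs from compound 1 at a different place on the shared core: cyclopentyl in place of methyl on a nitrogen on an aromatic ring

Going by the values given here, none of the measured steps touches this nitrogen on an aromatic ring; all of them concern the amide-type nitrogen on the other side of the core. The measured steps therefore bear on the new change only in a general sense: every enlargement seen so far has weakened binding in this assay, and the enlargement here is of comparable size in heavy atoms to the step from compound 1 to compound 2. Among the compounds with values here, a moderate rise in the number is expected, but with a wide range, since no direct precedent exists.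

Compound 4 is estimated at 2 nM, between 0.4 nM and 10 nM, which would mean an expected step of a 7.1-fold higher number from compound 1 to compound 4 (0.85 log units; beyond the scatter).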

Compound 4, inhibition constant: 4.27 nM
Beside the measured number, compound 4's estimate is 2.1-fold (0.33 log units) below it, and the stated range covers the measured number.
By their numbers in this assay, from the lowest: compound 1; then compound 2; then compound 4; then compound 3.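

In this assay, putting cyclopentyl in place of methyl on a nitrogen on an aromatic ring gives a 15-fold higher number from compound 1 to compound 4 (1.18 log units; beyond the scatter). Going by these compounds alone, this is the first step at this nitrogen, and it shows that the number responds to changes on this side of the shared core as well as to those on the amide-type nitrogen. The rise is large, yet compound 4 still gives 4.27 nM, so a five-membered carbon ring on this nitrogen does not abolish binding in this assay, and nothing at hand accounts for the rise.

As far as these compounds go, with only methyl and cyclopentyl on this nitrogen, it remains open how the number changes in the range between and beyond them, for example with an ethyl, a cyclopropyl, a cyclohexyl or a benzyl group. From the compounds shown here alone, it is also open whether the effects at the two sites add up, as a compound joining cyclopentylamino with the isobutyl or 3-fluorophenyl groups on the amide-type nitrogen would show.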